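The source may report more compounds than this note shows. Statements on the series, on what has been measured and on what is new or still open speak of the compounds shown alone.

In a functional assay on A549 cells (Homo sapiens) for inhibition, tested at 1 uM (on this read-out lower numbers stand for a weaker effect and higher numbers for a stronger effect at the one concentration tested), two compounds have been measured so far. Compound 1 `COc1ccc2c(c1)c(-c1cc(C(F)(F)F)c(C#N)c(-c3cn(S(=O)(=O)c4ccc(C)cc4)c4ccc(OC)cc34)n1)cn2S(=O)(=O)c1ccc(C)cc1` gives 24.4%. Compound 2 `Cc1ccc(S(=O)(=O)n2cc(-c3cc(C(F)(F)F)cc(-c4cn(S(=O)(=O)c5ccc(C)cc5)c5cc(Br)ccc45)n3)c3ccc(Br)cc32)cc1` gives 30.7%, a number that lies within the usual scatter of the number for compound 1, so the two read as equal. Compound 3 `Cc1ccc(S(=O)(=O)n2cc(-c3cc(C(F)(F)F)c(C#N)c(-c4cn(S(=O)(=O)c5ccc(C)cc5)c5cc(Br)ccc45)n3)c3ccc(Br)cc32)cc1` is compound 2 with a single change: cyano in place of hydrogen on an aromatic carbon. For the measured compounds named here, compound 1 also carries this cyano, but it differs from compound 2 in a second place as well, so no clean step for the cyano alone is known. The change is expected to give a number 2.7 percentage points lower from compound 2 to compound 3 (within the scatter), nothing beyond the scatter. Compound 3 is estimated at 28%, within a range from 12% to 45%.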

Compound 3, a percentage reported as inhibition, at one concentration (the size of the read-out at that concentration, not a potency): 18.8%
For compound 3 the middle estimate is 9.2 percentage points above the measured one; low and high end bracket the measured number.
By their numbers in this assay, from the lowest: compounds 3, 1 and 2 (each within the scatter of the next, the first and the last beyond it).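

In this assay, cyano in place of hydrogen on this aromatic carbon, ortho to a trifluoromethyl group and two atoms from the ring nitrogen, gives a number 11.9 percentage points lower from compound 2 to compound 3 (beyond the scatter). For the compounds shown here, this is the first clean reading of the change, and it shows that at this position cyano and hydrogen are not equivalent: the cyano compound inhibits modestly less at the one concentration tested. Nothing at hand explains this step. As far as these compounds go, whether an amine or a carboxylic acid on the same carbon would give less or more inhibition stays open. So does whether the cyano step would be the same on the core of compound 1.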